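Cyano in Place of Fluoro on the Benzyl Group

The compounds below may be only part of what the source reports. "The series", "measured", "known", "first", "only" and "open" are said of these compounds alone.

Three compounds have been measured in an ADME assay on HepG2 cells (Homo sapiens) for cytotoxicity, read by luminescence, CellTiter-Glo and ATP content, with a stated time of 72 h; a lower number here means that less compound is needed, a higher number that more compound is needed for the effect:

Compound 1 `c1ccc(-c2ccc3c(NCCCNCc4ccco4)ccnc3c2)cc1` gives 5920 nM
Compound 2 `Fc1ccc(-c2ccc3c(NCCCNCc4ccco4)ccnc3c2)cc1` gives 7760 nM
Compound 3 `Fc1ccc(Cc2ccc3c(NCCCNCc4ccco4)ccnc3c2)cc1` gives 5600 nM

All three share one core and differ only in the group hanging from it. Compound 3 sits within the scatter of both neighbours: a 1.1-fold lower number from compound 1 to compound 3 (0.02 log units; within the scatter) and a 1.4-fold lower number from compound 2 to compound 3 (0.14 log units; within the scatter). The unmeasured compound 4 `N#Cc1ccc(Cc2ccc3c(NCCCNCc4ccco4)ccnc3c2)cc1` differs from compound 3 by cyano in place of fluoro on an aromatic carbon. Among the measured compounds shown here, no measured step involves a cyano group. The only step touching the same place on the ring, a 1.3-fold higher number from compound 1 to compound 2 (0.12 log units; within the scatter), stayed within the scatter, as did every other step shown. On that basis compound 4 is expected to give 5600 nM, within a range from 2800 nM to 11200 nM, which is an expected step of no change at the digits printed from compound 3 to compound 4 (within the scatter).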

Compound 4, half-maximal effective concentration: 7910 nM
Estimate against measurement, compound 4: 1.4-fold (0.15 log units) below, and the stated range covers the measured number.
By their numbers in this assay, from the lowest: compounds 3, 1, 2 and 4 (each within the scatter of the next).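

Putting cyano in place of fluoro on this ring leaves the number within the scatter in this assay, with a 1.4-fold higher number from compound 3 to compound 4 (0.15 log units; within the scatter). The new 4-cyanobenzyl group also stays within the scatter when set against the groups at this place in the two earlier compounds, with a 1.0-fold higher number from compound 2 to compound 4 (0.01 log units; within the scatter) and a 1.3-fold higher number from compound 1 to compound 4 (0.13 log units; within the scatter). No measurement shown offers an explanation for this result.

Still open, on these data alone, is whether an amine or a carboxylic acid in place of the cyano would also stay within the scatter.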